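Aryloxy Swap on a Phosphoserine Ester Series

A few compounds are considered here, and "the series" means these few. Any claim that something is new, unique, unknown or untested is made for them only; others in the source may bear on it.

Measured so far:
compound 1, `CCCCCCCCCCCOc1ccccc1CCC(=O)OCCCOP(=O)(O)OC[C@H](N)C(=O)O`: 0.04
compound 2, `N[C@@H](COP(=O)(O)OCCCOC(=O)CCc1ccccc1OCc1cccc(Cc2ccccc2)c1)C(=O)O`: 0.077

In an assay on cells for activation of probable G-protein coupled receptor 34 (Mus musculus), with a stated time of 1 h (on this read-out higher numbers stand for larger maximal responses and lower numbers for smaller maximal responses), compound 1 gives 0.04, and compound 2 gives 0.077. These two numbers lie within the usual scatter of each other, so compound 2 cannot be set apart from compound 1 on this read-out; both show only a small maximal response against the reference agonist. Going by the values given here, no step between the two measured compounds is recorded here, since they differ in more than one place.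

Compound 3, `Cc1ccccc1Oc1cccc(COc2ccccc2CCC(=O)OCCCOP(=O)(O)OC[C@H](N)C(=O)O)c1`, has not yet been measured in this assay. It differs from compound 2 by 2-methylphenoxy in place of benzyl on an aromatic carbon. Among the compounds with values here, with only two measured compounds, both sitting at small maximal responses and indistinguishable within the scatter, there is no step in this assay on which to base a direction for this change. The step from compound 2 to compound 3 is therefore expected to be small, a number 0.013 higher from compound 2 to compound 3 (within the scatter), most likely within the scatter and of no clear direction. In this assay compound 3 is estimated at 0.09, with a range from 0.01 to 0.25.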

Compound 3, intrinsic activity: the largest response reached, as a fraction of the reference agonist's: 0.28
Estimate against measurement, compound 3: 0.19 below; measured number outside the range, above it.
By their numbers in this assay, from the lowest: compounds 1 and 2 (each within the scatter of the next); then compound 3.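

In this assay, going by these compounds alone, the aromatic carbon meta to a large group proves to be a place where the maximal response can move: 2-methylphenoxy in place of benzyl gives a number 0.20 higher from compound 2 to compound 3 (beyond the scatter) and so provides the first step that lies beyond the scatter. Even so, compound 3 reaches only 0.28 as a fraction of the reference agonist's response, so this change raises the maximal response without bringing it to the level of the reference. The swap brings in an ether oxygen, which is counted as a hydrogen-bond acceptor, and a methyl group together, and no measurement at hand explains the rise or assigns it to either feature.

The compounds shown leave open whether plain phenoxy, without the methyl group, would keep this higher response, and therefore whether the oxygen or the methyl group accounts for the step. They also leave open whether a smaller group on the same ring carbon, such as an amine or a carboxylic acid, would move the response in the same direction.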